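Inversion of a ring stereocentre: compound 3 to compound 4

This account rests on a few compounds, and the source may have more. Where it says the series, first, only, none or still open, it means among the compounds named here.

Measured in a functional assay on XF498 cells (Homo sapiens) for cytotoxicity; a higher number here means that more compound is needed for the effect, a lower number that less compound is needed:
compound 1 `CC1=C(O)[C@@H](C/C(C)=C\CC[C@H](C)/C=C/C=C(\C)CCCc2ccoc2)OC1=O`: 9.8 ug/mL
compound 2 `CC1=C(O)[C@@H](C/C(C)=C\CC[C@H](C)/C=C/C=C(\C)CCCC2=CCN(CCC(C)C)C2=O)OC1=O`: 3.9 ug/mL
compound 3 `CCC(C)CN1CC=C(CCC/C(C)=C/C=C/[C@@H](C)CC/C=C(/C)C[C@@H]2OC(=O)C(C)=C2O)C1=O`: 5.4 ug/mL

Compound 3 holds the second highest of the three numbers. Its nearest neighbour is compound 2, whose value lies within the scatter of that of compound 3, and its furthest is compound 1, which also stays within the scatter. Among the measured compounds shown here, the single step that goes beyond the scatter is a 2.5-fold lower number from compound 1 to compound 2 (0.40 log units; beyond the scatter), a replacement of one group by another, and it does not speak to the change at hand.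

Compound 4 `CCC(C)CN1CC=C(CCC/C(C)=C/C=C/[C@@H](C)CC/C=C(/C)C[C@H]2OC(=O)C(C)=C2O)C1=O` keeps every atom and bond of compound 3. (the two compounds have the same atoms and bonds; at least one stereo element is drawn with a configuration in one of them and without one in the other: 1 of 6 stereo elements differ; a stereocentre at a saturated ring carbon is drawn S in compound 3 and R in compound 4). No measured pair in this set differs by a stereocentre alone, so nothing shown tells how large such an inversion may be here; the only guide is that three compounds carrying rather different side groups all stay close to one another in this assay. For compound 4 the expectation is therefore no step beyond the scatter, no change at the digits printed from compound 3 to compound 4 (within the scatter). Compound 4 is estimated at 5.4 ug/mL, with a range from 2.5 ug/mL to 12 ug/mL.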

Compound 4, concentration for half-maximal effect: 25.2 ug/mL
Beside the measured number, compound 4's estimate is 4.7-fold (0.67 log units) below it; measured number outside the range, above it.
By their numbers in this assay, from the lowest: compounds 2, 3 and 1 (each within the scatter of the next, the first and the last beyond it); then compound 4.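

In this assay, among the compounds shown here, inverting this ring stereocentre gives a 4.7-fold higher number from compound 3 to compound 4 (0.67 log units; beyond the scatter), so a change of configuration alone can carry a step beyond the scatter, which the earlier compounds could not show. Compound 4 also stands apart from the compounds that differ from it in the side group: sec-butyl in place of isobutyl gives a 6.5-fold higher number from compound 2 to compound 4 (0.81 log units; beyond the scatter), and the group of 11 heavy atoms in place of the group of 5 heavy atoms gives a 2.6-fold higher number from compound 1 to compound 4 (0.41 log units; beyond the scatter). The step from compound 3 rests on a single feature: the fact that one of compounds 3 and 4 is drawn with a defined configuration and the other without, at the place where they differ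

As far as these compounds go, whether the same inversion has a similar effect with isobutyl on the amide-type nitrogen in the ring remains open. The same holds for a benzyl group or a longer chain on that nitrogen.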